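The compounds below may be only part of what the source reports. "The series", "measured", "known", "first", "only" and "open" are said of these compounds alone.

Of the compounds shown here, two with a shared core have numbers so far in an ADME assay on microsomes from liver (Rattus norvegicus) for metabolic stability, read by LC-MS, using NADPH, with stated times of 5 min and 60 min, tested at 4 uM; a lower number here means that less of the compound is left, a higher number that more of the compound is left. Compound 1 (`CC1=C(c2nc(-c3ccc(C#N)cc3)cs2)C(c2cc3ccccc3n2C)NC(=O)N1`) gives 62.9%, and compound 2 (`CC1=C(c2nc(-c3ccc(C#N)cc3)cs2)C(c2ccc(Cl)nc2)NC(=O)N1`) gives 63.4%, which places compound 2 level with compound 1 within the usual scatter of this measurement. Compound 3 (`CC1=C(c2nc(-c3ccc(C#N)cc3)cs2)C(c2ccc(Br)nc2)NC(=O)N1`) has not yet been measured and differs from compound 2 in one place: bromo in place of chloro on an aromatic carbon. In short, it carries bromo in place of chloro on an aromatic carbon.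

For the measured compounds named here, only one measured step can serve as a guide, and it is an indirect one: a number 0.5 percentage points higher from compound 1 to compound 2 (within the scatter). That step exchanged an entire group on a saturated ring carbon, yet the number stayed within the scatter. Going by the values given here, no measured pair swaps one halogen for another, so the data offer no direct precedent. The new change replaces a single heavy atom, and no shift beyond the scatter is expected in this assay. The estimated move is a number 1.4 percentage points lower from compound 2 to compound 3 (within the scatter), which is expected to be indistinguishable from no change. For compound 3 the expected value is 62%, with an estimated range from 50% to 73%.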

Compound 3, percent of the compound remaining: 67.6%
The estimate for compound 3 lay 5.6 percentage points below the measured number; low and high end bracket the measured number.
By their numbers in this assay, from the lowest: compounds 1, 2 and 3 (each within the scatter of the next).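

In this assay, bromo in place of chloro on the aromatic carbon next to the ring nitrogen gives a number 4.2 percentage points higher from compound 2 to compound 3 (within the scatter), the first direct view of one halogen exchanged for another at this place, and the step lies within the scatter. The larger exchange on the saturated ring carbon, 6-bromopyridin-3-yl in place of 1-methyl-1H-indol-2-yl, gives a number 4.7 percentage points higher from compound 1 to compound 3 (within the scatter), also within the scatter, so this read-out does not yet separate the three groups seen on that carbon. No supporting measurement bears on these results, so they stand without an explanation.

The compounds shown carry only chloro or bromo on this aromatic carbon, which leaves open whether a fluoro group, a methoxy group or an amine there would also stay within the scatter in this assay. Going by these compounds, the nitrile is the same in all three compounds, so it also remains open whether an amide or a carboxylic acid in its place would produce a step beyond the scatter.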